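A few compounds are considered here, and "the series" means these few. Any claim that something is new, unique, unknown or untested is made for them only; others in the source may bear on it.

Working notes on the series built on the core of compound 1 `O=C1CC(c2ccccc2)CN1c1cnn2c1CN(C(=O)Nc1cc(F)c(F)c(F)c1)C(C1CC1)C2`. Going by the values given here, in a toxicity assay on HepG2 2.2.15 cells (Homo sapiens) for cytotoxicity, read by CellTiter-Glo (a higher number here means that more compound is tolerated, a lower number that less compound is tolerated), compound 1 gives 12800 nM, the only plain number obtained so far. Compound 2 `O=C1CC(c2ccccc2)CN1c1cnn2c1CN(C(=O)Nc1cc(F)c(F)c(F)c1)C(Cc1ccccc1)C2` carries benzyl in place of cyclopropyl on a saturated ring carbon, and in this assay compound 2 is reported only as a limit, > 2000 nM. The step that the limit leaves unreadable from compound 1 to compound 2 cannot be sized because of the limit of > 2000 nM in this assay, at which 1 of the 2 values shown sits.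

Compound 3 `N#CC1CC(=O)N(c2cnn3c2CN(C(=O)Nc2cc(F)c(F)c(F)c2)C(C2CC2)C3)C1` is the unmeasured analogue. Against compound 1 the difference is cyano in place of phenyl on a saturated ring carbon. Among the compounds with values here, no measured step touches this part of the core; the single measured step sits on a different saturated ring carbon and is unreadable, so nothing in this set sizes the move. The working expectation for compound 3 in this assay is a step of a 1.2-fold higher number from compound 1 to compound 3 (0.07 log units; within the scatter) that stays within the usual scatter, with no direction claimed. Compound 3 is therefore estimated at 15000 nM, with a range from 5000 nM to 45000 nM.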

Compound 3, half-maximal cytotoxic concentration: > 200000 nM
Compound 3 gave a limit, no number (the forecaster's own chance of this, stated with the estimate: 35%); middle value at least 13-fold (1.12 log units) from the limit.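

In this assay, the saturated ring carbon two ring bonds from the ring nitrogen now has a readable step, which the earlier pair did not provide: cyano in place of phenyl gives an at least 15-fold higher number from compound 1 to compound 3 (1.19 log units; beyond the scatter). So, on the core of compound 1, the phenyl at this carbon is not neutral in this assay, and replacing it with the smaller cyano moves the reading well beyond the scatter. For compound 3, > 200000 nM is a limit and not a number, and the step can only be stated as a minimum because of this: the limit of > 200000 nM in this assay, at which 1 of the 3 values shown sits.

The compounds shown do not separate the departure of phenyl from the arrival of cyano, so a methyl, an amine or a carboxylic acid at this carbon would be needed to tell whether any replacement of phenyl gives a step of this size. On these data alone, the step from cyclopropyl to benzyl on the other saturated ring carbon cannot be read, so it remains open whether that position matters to the same extent.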